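Trifluoromethoxyphenyl Replaces Fluorophenyl on the Chain Carbon

The source may hold more compounds than are shown below. What is called first, only, known or untested is meant among the compounds shown, and "the series" means these compounds.

compound 1 `Cc1cc(Nc2ccc(C(=O)/C=C/c3ccccc3)cc2)n2nc(SCc3nc4ccccc4[nH]3)nc2n1`: 130 nM
compound 2 `Cc1cc(Nc2ccc(C(=O)/C=C/c3ccc(C(F)(F)F)cc3)cc2)n2nc(SCc3nc4ccccc4[nH]3)nc2n1`: 1850 nM
compound 3 `Cc1cc(Nc2ccc(C(=O)/C=C/c3ccccc3F)cc2)n2nc(SCc3nc4ccccc4[nH]3)nc2n1`: 250 nM

In a functional assay on SW-620 cells (Homo sapiens) for cytotoxicity, read by MTT assay, with stated times of 4 h and 72 h, tested at 2 uM (on this read-out higher numbers stand for weaker inhibition and lower numbers for stronger inhibition), compound 3 holds the second highest number of the three. Its nearest neighbour is shown by a 1.9-fold higher number from compound 1 to compound 3 (0.28 log units; within the scatter), which lies within the scatter; its furthest is shown by a 7.4-fold lower number from compound 2 to compound 3 (0.87 log units; beyond the scatter). Compound 4 `Cc1cc(Nc2ccc(C(=O)/C=C/c3ccc(OC(F)(F)F)cc3)cc2)n2nc(SCc3nc4ccccc4[nH]3)nc2n1` differs from compound 3 in one place: 4-(trifluoromethoxy)phenyl in place of 2-fluorophenyl on a double-bonded chain carbon bound to a double-bonded chain carbon. The step that bears on this is a 14-fold higher number from compound 1 to compound 2 (1.15 log units; beyond the scatter), a large shift toward weaker inhibition when a trifluoromethyl-bearing ring was placed on the same double-bonded chain carbon. Compound 4 carries a closely related 4-(trifluoromethoxy)phenyl there, so a weaker result is expected. Compound 4 is therefore estimated at 1200 nM, with a range from 400 nM to 3500 nM, an expected step of a 4.8-fold higher number from compound 3 to compound 4 (0.68 log units; beyond the scatter).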

Compound 4, half-maximal inhibitory concentration: 220 nM
Beside the measured number, compound 4's estimate is 5.5-fold (0.74 log units) above it, outside the stated range (below it).
By their numbers in this assay, from the lowest: compounds 1, 4 and 3 (each within the scatter of the next); then compound 2.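

The loss seen with 4-(trifluoromethyl)phenyl on this double-bonded chain carbon does not carry over to its close relative in this assay: trifluoromethoxy in place of trifluoromethyl gives a clear recovery (an 8.4-fold lower number from compound 2 to compound 4 (0.92 log units; beyond the scatter)). Compound 4 cannot be told apart from the fluoro compound (a 1.1-fold lower number from compound 3 to compound 4 (0.06 log units; within the scatter)) or the unsubstituted parent (a 1.7-fold higher number from compound 1 to compound 4 (0.23 log units; within the scatter)). Among these four compounds, only compound 2 stands apart.

Nothing shown explains why trifluoromethyl and trifluoromethoxy differ so sharply. Going by these compounds, whether an amine or a carboxylic acid on this ring would also match compound 1 remains open.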